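This account rests on a few compounds, and the source may have more. Where it says the series, first, only, none or still open, it means among the compounds named here.

Of the compounds shown here, three have been measured in a functional assay on HepG2 cells (Homo sapiens) for inhibition, read by MTT assay, with a stated time of 72 h; a lower number here means a stronger inhibitor, a higher number a weaker inhibitor. Compound 1 `CC(C)CCN(CCCCCCC(=O)NO)c1ncc(C(=O)NCc2cccnc2)s1` gives 7000 nM, compound 2 `O=C(CCCCCN(Cc1ccc(F)cc1)c1ncc(C(=O)NCCCn2ccnc2)s1)NO` gives 30000 nM and compound 3 `O=C(CCCCCCN(Cc1ccc(F)cc1)c1ncc(C(=O)NCCCn2ccnc2)s1)NO` gives 9400 nM. Going by the values given here, the only measured step that changes a single place is (hydroxycarbamoyl)methyl in place of hydroxycarbamoyl, which gives a 3.2-fold lower number from compound 2 to compound 3 (0.50 log units; beyond the scatter). Compound 3 thus stands clearly apart from compound 2, while its value and that of compound 1 lie within the scatter of each other.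

Compound 4 `O=C(CCCCCCN(Cc1ccc(F)cc1)c1ncc(C(=O)NCc2cccnc2)s1)NO` differs from compound 3 in one place: pyridin-3-yl in place of 2-(1H-imidazol-1-yl)ethyl on a saturated chain carbon bound to an amide-type nitrogen. In words, pyridin-3-yl takes the place of 2-(1H-imidazol-1-yl)ethyl on a saturated chain carbon bound to an amide-type nitrogen. Among the compounds with values here, the one measured step concerns a different part of the molecule and does not measure this swap, so it offers no size to carry over. The closest evidence is indirect: compound 4 shares its ((pyridin-3-yl)methyl)carbamoyl with compound 1, which gives 7000 nM but differs from compound 4 elsewhere. With nothing pointing firmly either way, no change beyond the scatter is expected in this assay, and the expected step is a 1.2-fold lower number from compound 3 to compound 4 (0.07 log units; within the scatter). For compound 4 the estimated value is 8000 nM, with an expected range of 3500 nM to 18000 nM.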

Compound 4, half-maximal inhibitory concentration: 14000 nM
Compound 4: middle estimate off by 1.8-fold (0.24 log units), on the low side; low and high end bracket the measured number.
By their numbers in this assay, from the lowest: compounds 1, 3 and 4 (each within the scatter of the next); then compound 2.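

In this assay, swapping the (3-(1H-imidazol-1-yl)propyl)carbamoyl of compound 3 for the ((pyridin-3-yl)methyl)carbamoyl of compound 4 gives a 1.5-fold higher number from compound 3 to compound 4 (0.17 log units; within the scatter), so this side group has now been varied on its own and the two compounds cannot be told apart. A second single-place comparison is also now available at a different part of the molecule: 4-fluorophenyl in place of isobutyl on a saturated chain carbon bound to a nitrogen on an aromatic ring gives a 2.0-fold higher number from compound 1 to compound 4 (0.30 log units; within the scatter), and this pair also cannot be told apart. No supporting measurement bears on either result, so neither can be tied to any property of the groups involved.

From the compounds shown here alone, it remains open whether an amine or a carboxylic acid on the side chain in place of pyridin-3-yl would give a step beyond the scatter. Going by these compounds alone, it is also open whether a longer chain leading to the hydroxycarbamoyl group would extend the one clear step so far, a 3.2-fold lower number from compound 2 to compound 3 (0.50 log units; beyond the scatter), or reverse it.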